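Trimethoxybenzoyl aminothiophene series: phenyl substitution and antiproliferative potency

This account rests on a few compounds, and the source may have more. Where it says the series, first, only, none or still open, it means among the compounds named here.

Compound 1 `COc1cc(C(=O)c2sc(-c3ccc(Cl)c(Cl)c3)cc2N)cc(OC)c1OC`: 290 nM
Compound 2 `CCOc1ccc(-c2cc(N)c(C(=O)c3cc(OC)c(OC)c(OC)c3)s2)cc1`: 270 nM
Compound 3 `COc1cc(C(=O)c2sc(-c3ccccc3)cc2N)cc(OC)c1OC`: 4.5 nM

In a functional assay on CCRF-CEM cells (Homo sapiens) for antiproliferative activity (on this read-out lower numbers stand for stronger inhibition and higher numbers for weaker inhibition), compound 3 gives the lowest number of the three, with compound 2 the nearest at a 60-fold lower number from compound 2 to compound 3 (1.78 log units; beyond the scatter) and compound 1 the furthest at a 64-fold lower number from compound 1 to compound 3 (1.81 log units; beyond the scatter). Compound 1 and compound 2 sit close together, a 1.1-fold lower number from compound 1 to compound 2 (0.03 log units; within the scatter), so the two substituted phenyl groups behave alike on this read-out, while the bare phenyl of compound 3 stands well apart from both.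

Compound 4 `COc1ccc(-c2cc(N)c(C(=O)c3cc(OC)c(OC)c(OC)c3)s2)cc1` is the next member, and the change from compound 3 reads: methoxy in place of hydrogen on an aromatic carbon. For the measured compounds named here, two measured steps bear on it. Going from compound 2 to compound 3 removes an ethoxy from the same place and lowers the number steeply, a 60-fold lower number from compound 2 to compound 3 (1.78 log units; beyond the scatter); going from compound 1 to compound 3 strips a differently substituted phenyl back to bare phenyl with a similar result, a 64-fold lower number from compound 1 to compound 3 (1.81 log units; beyond the scatter). Putting a methoxy onto the phenyl of compound 3 is therefore expected to cost potency in this assay by a large margin, in the direction of the substituted analogues.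

Compound 4 is estimated at 150 nM, within 40 nM to 600 nM, which is expected to amount to a 33-fold higher number from compound 3 to compound 4 (1.52 log units; beyond the scatter).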

Compound 4, half-maximal inhibitory concentration: 19 nM
Beside the measured number, compound 4's estimate is 7.9-fold (0.90 log units) above it; measured number outside the range, below it.
By their numbers in this assay, from the lowest: compound 3; then compound 4; then compounds 2 and 1 (each within the scatter of the next).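

In this assay, the para position of the phenyl ring separates two small alkoxy groups sharply: methoxy in place of hydrogen carries only a modest penalty (a 4.2-fold higher number from compound 3 to compound 4 (0.63 log units; beyond the scatter)), whereas trimming ethoxy to methoxy recovers most of the lost potency (a 14-fold lower number from compound 2 to compound 4 (1.15 log units; beyond the scatter)), so this place responds to a single added methyl on the chain rather than to the mere presence of an alkoxy group. The earlier match between the 3,4-dichlorophenyl and 4-ethoxyphenyl analogues therefore does not extend to every substituted phenyl, since 4-methoxyphenyl stands well apart from 3,4-dichlorophenyl (a 15-fold lower number from compound 1 to compound 4 (1.18 log units; beyond the scatter)) while bare phenyl still gives the lowest number of the series. No measurement here accounts for why one extra methyl matters so much at this position.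

The compounds shown leave open how a propoxy chain, a hydroxyl or an amine would read in this same place, and so whether the rise from methoxy to ethoxy continues or levels off. They also leave open whether a single chlorine behaves more like methoxy or like the 3,4-dichlorophenyl pattern.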